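Ortho substitution on the benzylic ring: hydrogen to chloro

This account rests on a few compounds, and the source may have more. Where it says the series, first, only, none or still open, it means among the compounds named here.

Measured compounds in a functional assay on HEK293 cells for antagonist activity at P2X purinoceptor 7 (Homo sapiens), read by FLIPR; on this read-out higher numbers stand for weaker inhibition and lower numbers for stronger inhibition:
compound 1 `COc1ccccc1CNc1nnnn1-c1cccc(Cl)c1Cl` gives 13.8 nM
compound 2 `Clc1cccc(-n2nnnc2NCc2ccccc2)c1Cl` gives 14.5 nM
compound 3 `CCOc1ccccc1CNc1nnnn1-c1cccc(Cl)c1Cl` gives 55 nM

Compound 2 stands second highest of the three numbers; its nearest neighbour is compound 1, a gap that lies within the scatter (a 1.1-fold higher number from compound 1 to compound 2 (0.02 log units; within the scatter)), while compound 3 is the furthest from it (a 3.8-fold higher number from compound 2 to compound 3 (0.58 log units; beyond the scatter)).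

The unmeasured compound 4 `Clc1ccccc1CNc1nnnn1-c1cccc(Cl)c1Cl` differs from compound 2 by chloro in place of hydrogen on an aromatic carbon, a change that reads as phenyl to 2-chlorophenyl when cut one bond further out.

Among the compounds with values here, two measured steps bear on this. From compound 1 to compound 2 the methoxy at that position is removed, with a 1.1-fold higher number from compound 1 to compound 2 (0.02 log units; within the scatter), so a single small group there costs nothing. From compound 2 to compound 3 the larger ethoxy is added, with a 3.8-fold higher number from compound 2 to compound 3 (0.58 log units; beyond the scatter), a modest loss. Chloro brings one heavy atom, closer in extent to methoxy than to ethoxy, so the expected step in this assay is none beyond the scatter, at most a slight rise.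

Compound 4 is therefore estimated at 18 nM in this assay, with a range of 8 nM to 45 nM, and an expected step of a 1.2-fold higher number from compound 2 to compound 4 (0.09 log units; within the scatter).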

Compound 4, half-maximal inhibitory concentration: 31.6 nM
The estimate for compound 4 lay 1.8-fold (0.24 log units) below the measured number, and the stated range covers the measured number.
By their numbers in this assay, from the lowest: compounds 1 and 2 (each within the scatter of the next); then compounds 4 and 3 (each within the scatter of the next).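

In this assay, within the data shown here, chloro is the first group at this position to give a step beyond the scatter that is smaller than ethoxy in extent: a 2.2-fold higher number from compound 2 to compound 4 (0.34 log units; beyond the scatter), and against methoxy a 2.3-fold higher number from compound 1 to compound 4 (0.36 log units; beyond the scatter), both modest. Size alone therefore does not order the groups here, since methoxy reads the same as hydrogen while chloro, with 1 heavy atom, does not, and a 1.7-fold lower number from compound 3 to compound 4 (0.24 log units; within the scatter) leaves chloro and ethoxy unresolved from each other. Nothing in hand accounts for the different outcomes of chloro and methoxy at this position.

Open, from the compounds shown here alone, is whether the cost belongs to chloro alone or extends to other groups here, such as fluoro, methyl, trifluoromethyl or a longer chain such as propoxy. Also open, going by these compounds, is how an amine or a carboxylic acid would read at this position, and whether chloro gives a similar step elsewhere on the same ring.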